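Bromo for Hydrogen on Two Cores: Growth Inhibition Notes

The source may hold more compounds than are shown below. What is called first, only, known or untested is meant among the compounds shown, and "the series" means these compounds.

Measured compounds:
- compound 1, `COc1ccc(C2CC(c3ccccc3)=NN2C2=NC(=O)/C(=C3\C(=O)Nc4ccccc43)S2)cc1`: 1620 nM
- compound 2, `COc1ccc(C2CC(c3ccccc3)=NN2C2=NC(=O)/C(=C3\C(=O)Nc4ccc(Br)cc43)S2)cc1`: 180 nM
- compound 3, `COc1ccc(C2=NN(C3=NC(=O)/C(=C4\C(=O)Nc5ccccc54)S3)C(c3ccc(Cl)cc3)C2)cc1`: 77500 nM

In a functional assay on cells (Cancer cell lines, Homo sapiens) for cytotoxicity, read by sulforhodamine B assay, with a stated time of 48 h (a lower number here means a stronger inhibitor of growth, a higher number a weaker inhibitor of growth), compound 1 gives 1620 nM and compound 2 gives 180 nM. Compound 2 differs from compound 1 by bromo in place of hydrogen on an aromatic carbon. This change produced a 9.0-fold lower number from compound 1 to compound 2 (0.95 log units; beyond the scatter), a step that lies beyond the scatter of the method.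

Compound 3 is built on a different core; the difference between the two cores is not broken down here. In this assay compound 3 gives 77500 nM, the highest number among the three measured compounds, well beyond the scatter from both compound 1 and compound 2.

Compound 4, `COc1ccc(C2=NN(C3=NC(=O)/C(=C4\C(=O)Nc5ccc(Br)cc54)S3)C(c3ccc(Cl)cc3)C2)cc1`, has not yet been measured. It differs from compound 3 by bromo in place of hydrogen on an aromatic carbon, the same change at the same kind of place as that from compound 1 to compound 2. Among the measured compounds shown here, the step from compound 3 to compound 4 in this assay is expected to be of similar size, an 8.6-fold lower number from compound 3 to compound 4 (0.94 log units; beyond the scatter), because the only precedent in this set is a 9.0-fold lower number from compound 1 to compound 2 (0.95 log units; beyond the scatter). The expectation carries real uncertainty, since it rests on a single pair and the core of compound 3 is not the core of compound 1. For compound 4 the estimate in this assay is 9000 nM, with a plausible range from 2500 nM to 40000 nM.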

Compound 4, concentration for 50% growth inhibition: 120 nM
The estimate for compound 4 lay 75-fold (1.88 log units) above the measured number; the measured number lies below the stated range.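

In this assay, bromo in place of hydrogen on an aromatic carbon lowers the number on both cores, and on the core of compound 3 the result is a 650-fold lower number from compound 3 to compound 4 (2.81 log units; beyond the scatter), so the direction of the change carries from one core to the other in the two pairs available. The size of the change does not carry over, and a step taken from one core is a poor guide to the step on the other: the same change on two cores in this assay, a 9.0-fold lower number (0.95 log units; beyond the scatter) from compound 1 to compound 2 and a 650-fold lower number (2.81 log units; beyond the scatter) from compound 3 to compound 4, 72-fold (1.86 log units) apart, beyond the scatter of two such steps This does not show which structural difference between the cores goes with the larger step, since they differ in more than one place, and two pairs give no general rule for the series or any account of the mechanism behind the gap.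

On these data alone, it remains open whether this core dependence belongs to bromo itself or would also appear with fluoro, a methyl group, a nitrile or an amine on the same aromatic carbon. As far as these compounds go, it also remains open whether the large step on the core of compound 3 would persist if the chloro on that core were replaced by hydrogen or methoxy, which would help separate the parts of the core that differ.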